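Replacing a Methylamino Group with a Dimethyl-Oxolane Ring

The compounds below may be only part of what the source reports. "The series", "measured", "known", "first", "only" and "open" are said of these compounds alone.

Three compounds sharing one core have been measured in an assay on isolated protein for inhibition of activin receptor type-2A (Homo sapiens), read by 33P incorporation, with a stated time of 20 min, in the presence of a further agent that is not named here; a higher number here means a weaker inhibitor, a lower number a stronger inhibitor:

Compound 1, `COc1cc(-c2cnn3cc(OC)c(-c4cc(C)no4)nc23)ccn1`: 3000 nM
Compound 2, `COc1cc(-c2cnn3cc(OC)c(C4CCOC4)nc23)ccn1`: 1900 nM
Compound 3, `CNc1nc2c(-c3ccnc(OC)c3)cnn2cc1OC`: 310 nM

Compound 3 gives the lowest number of the three. Its nearest neighbour is compound 2, with a 6.1-fold lower number from compound 2 to compound 3 (0.79 log units; beyond the scatter), and the widest gap is to compound 1, with a 9.7-fold lower number from compound 1 to compound 3 (0.99 log units; beyond the scatter). Both of those gaps lie beyond the scatter, so compound 3 is the strongest inhibitor among the measured set. Compound 1 and compound 2 differ from each other only within the scatter, as a 1.6-fold lower number from compound 1 to compound 2 (0.20 log units; within the scatter) shows.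

Compound 4, `COc1cc(-c2cnn3cc(OC)c([C@H]4COC(C)(C)C4)nc23)ccn1`, is not yet measured. It differs from compound 3 in one place: a group of 7 heavy atoms (6 carbon, 1 oxygen; one five-membered non-aromatic ring with 1 hetero atom) in place of a group of 2 heavy atoms (1 carbon, 1 nitrogen; no ring), on an aromatic carbon

The step that bears most directly on this change runs the other way, from compound 2 to compound 3, where oxolan-3-yl gave way to methylamino and the number fell by a 6.1-fold lower number from compound 2 to compound 3 (0.79 log units; beyond the scatter). Compound 4 brings back a five-membered ring with one oxygen at the same position, now carrying a defined stereocentre and two extra carbons, so the number is expected to rise again toward the values of compound 1 and compound 2. The expected step is a 4.8-fold higher number from compound 3 to compound 4 (0.68 log units; beyond the scatter). Compound 4 is therefore estimated at 1500 nM, with a likely range from 500 nM to 4500 nM.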

Compound 4, half-maximal inhibitory concentration: 4100 nM
Compound 4: the middle estimate sits 2.7-fold (0.44 log units) below what was measured; low and high end bracket the measured number.
By their numbers in this assay, from the lowest: compound 3; then compounds 2, 1 and 4 (each within the scatter of the next, the first and the last beyond it).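

At this position on the aromatic carbon, exchanging the methylamino group for the substituted oxolane ring in this assay gives a 13-fold higher number from compound 3 to compound 4 (1.12 log units; beyond the scatter), the largest step among the compounds shown. The closest comparison is with the plain oxolan-3-yl group, where the added ring carbons and the defined stereocentre give a 2.2-fold higher number from compound 2 to compound 4 (0.33 log units; beyond the scatter), so this substituted ring does not recover the strength of compound 3 and instead gives a weaker inhibitor than the plain ring. Set against the 3-methyl-1,2-oxazol-5-yl group, the new ring gives a 1.4-fold higher number from compound 1 to compound 4 (0.14 log units; within the scatter), so those two groups cannot be told apart, and all three ring-bearing compounds are weaker inhibitors than the methylamino compound, with none going against this within the set.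

The compounds shown do not separate the effect of the added carbons from that of the stereocentre, and they leave open whether a plain amino group or an ethylamino group would match or better methylamino here. Nothing measured here explains why methylamino gives the lowest number at this position.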